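Furan for thiophene on the pyrrolopyrimidine nucleoside core

The compounds below may be only part of what the source reports. "The series", "measured", "known", "first", "only" and "open" are said of these compounds alone.

Measured so far:
compound 1, `O=c1[nH]cnc2c1c(-c1cccs1)cn2[C@@H]1O[C@H](CO)[C@@H](O)[C@H]1O`: > 20000 nM
compound 2, `COc1nc(N)nc2c1c(-c1ccsc1)cn2[C@@H]1O[C@H](CO)[C@@H](O)[C@H]1O`: > 20000 nM
compound 3, `COc1nc(N)nc2c1c(-c1cccs1)cn2[C@@H]1O[C@H](CO)[C@@H](O)[C@H]1O`: > 20000 nM

In a functional assay on HL-60 cells (Homo sapiens) for antiproliferative activity, read by XTT assay, with a stated time of 72 h (on this read-out higher numbers stand for weaker inhibition and lower numbers for stronger inhibition), compound 1 gives > 20000 nM, a limit of the assay and not a number. Compound 2 also gives a limit, > 20000 nM. Compound 3 likewise gives a limit, > 20000 nM. Compound 1 therefore cannot be placed against the other two: the limit of > 20000 nM in this assay, at which 3 of the 3 values shown sit, so no order among them is readable. Within the data shown here, the only step between measured compounds, a step that the two limits leave unreadable from compound 2 to compound 3, is also unreadable.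

The new compound 4, `O=c1[nH]cnc2c1c(-c1ccco1)cn2[C@@H]1O[C@H](CO)[C@@H](O)[C@H]1O`, differs from compound 1 as follows: furan-2-yl in place of thiophen-2-yl on an aromatic carbon. Among the measured compounds shown here, no measured step bears on this change, and the values shown give no reading of any group at this position. The expectation for the step that the limit leaves unreadable from compound 1 to compound 4 is therefore that compound 4 stays at the limit. Compound 4 is estimated at 30000 nM, in the range 10000 nM to 100000 nM, most likely reported only as a limit in this assay.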

Compound 4, half-maximal inhibitory concentration: 2200 nM
Compound 4: middle estimate off by 14-fold (1.13 log units), on the high side; the whole stated range lies above it.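

In this assay, furan-2-yl in place of thiophen-2-yl gives an at least 9.0-fold lower number from compound 1 to compound 4 (0.95 log units; beyond the scatter), so this position can move a compound of the series off the limit. The two groups have the same counts of heavy atoms, donors and acceptors and differ in one ring atom, oxygen for sulfur, so that single exchange is enough to give a measurable value on the core of compound 1. Compound 4 is the only compound shown with a number rather than a limit: the limit of > 20000 nM in this assay, at which 3 of the 4 values shown sit.

From the compounds shown here alone, the steps among the compounds at the limit cannot be read, so whether furan-2-yl would give a similar step on the core of compound 2 remains open. Also open, going by these compounds, is how a phenyl ring, an amine or a short alkyl chain at this position would compare with furan-2-yl.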